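This account rests on a few compounds, and the source may have more. Where it says the series, first, only, none or still open, it means among the compounds named here.

Measured so far:
- Compound 1 `COC1=C(C)C(=O)/C(=C(O)/C=C/c2ccccc2C)C(=O)C1(C)C`: 5.2 ug/mL
- Compound 2 `CCCC1=C(OC)C(CCC)(CCC)C(=O)/C(=C(O)\C=C\c2ccccc2)C1=O`: 1.9 ug/mL

In a functional assay on A-431 cells (Homo sapiens) for cytotoxicity (a higher number here means that more compound is needed for the effect, a lower number that less compound is needed), compound 2 gives 1.9 ug/mL, the lower of the two numbers, while compound 1 gives 5.2 ug/mL, a gap that lies beyond the usual scatter. For the measured compounds named here, these two compounds differ in more than one place, and no measured pair isolates a single change.

Compound 3 `CCCC1=C(OC)C(CCC)(CCC)C(=O)/C(=C(O)\C=C\c2ccc(Br)cc2)C1=O` differs from compound 2 in one place: bromo in place of hydrogen on an aromatic carbon. It has bromo in place of hydrogen on an aromatic carbon, para to a large group. Going by the values given here, with no measured precedent for this change, the expectation is a small shift at most, with none beyond the scatter as the likeliest outcome. The expected move is a 1.1-fold lower number from compound 2 to compound 3 (0.05 log units; within the scatter). In this assay the estimated value for compound 3 is 1.7 ug/mL, with an expected range of 0.7 ug/mL to 4.2 ug/mL.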

Compound 3, concentration for half-maximal effect: 1.2 ug/mL
Compound 3: middle estimate off by 1.4-fold (0.15 log units), on the high side; low and high end bracket the measured number.
By their numbers in this assay, from the lowest: compounds 3 and 2 (each within the scatter of the next); then compound 1.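

In this assay, for the compounds shown here, the step of a 1.6-fold lower number from compound 2 to compound 3 (0.20 log units; within the scatter) is the first comparison that isolates a single change. It shows that bromo in place of hydrogen on an aromatic carbon, para to a large group, is tolerated on the shared core, since phenyl and 4-bromophenyl cannot be told apart in this read-out. The earlier pair differed in more than one place and could not speak to this position alone, and no outside information bears on this result.

A single halogen leaves open whether a larger or differently built substituent here, such as a methoxy group, an amine or a carboxylic acid, would also leave the number within the scatter. From the compounds shown here alone, it is also open whether bromo would give the same result elsewhere on this ring or on the core of compound 1.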